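This account rests on a few compounds, and the source may have more. Where it says the series, first, only, none or still open, it means among the compounds named here.

Measured so far:
compound 1 `CN(C)C(=O)CN1CCC(c2cc3c(-c4ccc(=O)n(C5CCC5)c4)ccnc3[nH]2)CC1` in a physicochemical assay for lipophilicity, using the shake flask method, measured as octanol-water partition, at pH 7.4 (on this read-out lower numbers stand for lower lipophilicity and higher numbers for higher lipophilicity), gives 1.9
compound 2 `CN(C)C(=O)CN1CCC(c2cc3c(-c4ccc(=O)n(C5CCOCC5)c4)ccnc3[nH]2)CC1` in this assay gives 1.1
compound 3 `CC(C)Cn1cc(-c2ccnc3[nH]c(C4CCN(CC(=O)N(C)C)CC4)cc23)ccc1=O` in this assay gives 2

Compound 3 has the highest of the three numbers, but compound 1 lies within the scatter of it, so no order between those two can be read. Only compound 2 stands apart: the step of a number 0.90 log units higher from compound 2 to compound 3 (beyond the scatter) is beyond the scatter.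

Compound 4 `CN(C)C(=O)CN1CCC(c2cc3c(-c4ccc(=O)n(CCC5CCOCC5)c4)ccnc3[nH]2)CC1` is not yet measured. It differs from compound 3 by (oxan-4-yl)methyl in place of isopropyl on a saturated chain carbon bound to an aromatic nitrogen. Going by the values given here, two measured steps bear on this: a number 0.80 log units lower from compound 1 to compound 2 (beyond the scatter) and a number 0.90 log units higher from compound 2 to compound 3 (beyond the scatter). In both, the compound carrying the oxan-4-yl group, compound 2, gives the lower number. Compound 4 carries the same ring, set further out from the aromatic nitrogen on a longer chain than in compound 2, so a step down beyond the scatter is expected, though somewhat smaller than those two steps.

Compound 4 is therefore expected to give 1.4, within 0.9 to 1.9. This estimate means a step of a number 0.60 log units lower from compound 3 to compound 4 (beyond the scatter).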

Compound 4, distribution coefficient: 1.5
Estimate against measurement, compound 4: 0.10 log units below, and the stated range covers the measured number.
By their numbers in this assay, from the lowest: compound 2; then compound 4; then compounds 1 and 3 (each within the scatter of the next).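

Going by these compounds alone, with the oxan-4-yl ring set further out on a chain, the number in this assay falls in between those of the earlier compounds: a number 0.40 log units higher from compound 2 to compound 4 (beyond the scatter), but also a number 0.40 log units lower from compound 1 to compound 4 (beyond the scatter) and a number 0.50 log units lower from compound 3 to compound 4 (beyond the scatter). The presence of the ring therefore does not fix the number at this position, as the length of the link to the aromatic nitrogen also matters, and compound 4 carries a larger group than compound 3 yet reads lower, so group size alone does not order these compounds. Nothing measured here gives a reason for these steps.

Going by these compounds, whether a longer chain carrying the same ring would move the number further upward remains open. Also open is how an amine or a carboxylic acid on this nitrogen substituent would read, as every group shown here carries no net charge.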